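Removing the chloro group from the aromatic nitrogen substituent

The compounds below may be only part of what the source reports. "The series", "measured", "known", "first", "only" and "open" are said of these compounds alone.

Compound 2 `NC(=O)c1ccc2c(c1)nc(Nc1ccc(S(N)(=O)=O)cc1)n2Cc1csc2ccc(Cl)cc12` carries a (5-chloro-1-benzothiophen-3-yl)methyl group on the aromatic nitrogen of the shared core. In an assay on isolated protein for inhibition of kinesin heavy chain isoform 5A (Homo sapiens) (a lower number here means a stronger inhibitor, a higher number a weaker inhibitor), compound 2 reports only a limit, > 50000 nM. Compound 1 `NC(=O)c1ccc2c(c1)nc(Nc1ccc(S(N)(=O)=O)cc1)n2C1(c2ccccc2)CC1`, with 1-phenylcyclopropyl in that position, likewise reports only a limit in this assay, > 50000 nM. The step from compound 1 to compound 2, a step that the two limits leave unreadable from compound 1 to compound 2, thus carries no readable size. Where compound 2 stands on the numbers shown: the limit of > 50000 nM in this assay, at which 2 of the 2 values shown sit. Compound 3 `NC(=O)c1ccc2c(c1)nc(Nc1ccc(S(N)(=O)=O)cc1)n2Cc1csc2ccccc12` differs from compound 2 by hydrogen in place of chloro on an aromatic carbon. No measured step removes a chloro group from this substituent, and the single step shown is unreadable; a step of no readable size, a step that the limit leaves unreadable from compound 2 to compound 3, is therefore expected, with the result most likely once more a limit. Compound 3 is estimated at 60000 nM, within 20000 nM to 200000 nM.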

Compound 3, half-maximal inhibitory concentration: > 50000 nM
Compound 3 ended at the assay's limit; the forecaster's own chance of this, stated with the estimate: 85%; the middle value is on the limit's open side.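

Compound 3 gives > 50000 nM in this assay, a limit and not a number. Going by these compounds alone, no step among compound 1, compound 2 and compound 3 can be read: the limit of > 50000 nM in this assay, at which 3 of the 3 values shown sit. The compounds shown leave open whether the chloro group or either substituent on the aromatic nitrogen affects inhibition in this assay at all.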